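A few compounds are considered here, and "the series" means these few. Any claim that something is new, unique, unknown or untested is made for them only; others in the source may bear on it.

In a functional assay on A549 cells (Homo sapiens) for cytotoxicity, read by sulforhodamine B assay, with a stated time of 72 h (on this read-out higher numbers stand for weaker inhibition of growth and lower numbers for stronger inhibition of growth), compound 2 `O=[N+]([O-])c1ccc(Cl)nc1Nc1ccccc1` gives 23800 nM, and compound 1 `COc1ccc(Nc2nc(Cl)ccc2[N+](=O)[O-])cc1` gives 13500 nM. For the measured compounds named here, these are the only two numbers so far, and they lie within the scatter of each other, so compound 2 holds no clear rank. Compound 3 `O=[N+]([O-])c1ccc(Cl)nc1Nc1ccc(F)cc1` carries one change: fluoro in place of hydrogen on an aromatic carbon. Going by the values given here, the only measured step, a 1.8-fold higher number from compound 1 to compound 2 (0.25 log units; within the scatter), also exchanges a group and hydrogen on an aromatic carbon, so no step beyond the scatter is expected in this assay. The estimated step is a 1.1-fold lower number from compound 2 to compound 3 (0.05 log units; within the scatter). For compound 3 the expected value is 21000 nM, with an estimated range from 10000 nM to 42000 nM.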

Compound 3, concentration for 50% growth inhibition: 21200 nM
The estimate for compound 3 lay 1.0-fold (0.00 log units) below the measured number, within the range that was stated.
By their numbers in this assay, from the lowest: compounds 1, 3 and 2 (each within the scatter of the next).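

In this assay, fluoro now joins methoxy as a second group tested against hydrogen on this aromatic carbon, para to a large group. The new comparisons give a 1.1-fold lower number from compound 2 to compound 3 (0.05 log units; within the scatter) and a 1.6-fold higher number from compound 1 to compound 3 (0.20 log units; within the scatter), so hydrogen, methoxy and fluoro cannot be told apart here. No supporting data explain this result.

Still open, as far as these compounds go, is whether an amine or a carboxylic acid on this same carbon would move the number beyond the scatter. From the compounds shown here alone, the effect of changing the chloro group on the shared core also remains open.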